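Pyrrole for Thiophene on the Amide Carbonyl

The source may report more compounds than this note shows. Statements on the series, on what has been measured and on what is new or still open speak of the compounds shown alone.

Compounds measured in an assay on CHO cells for displacement of a labelled ligand from Alpha-1B adrenergic receptor (Homo sapiens); on this read-out lower numbers stand for stronger inhibition and higher numbers for weaker inhibition:
compound 1, `COc1cc2nc(N3CCN(C(=O)c4ccc(C(C)=O)o4)[C@H]4CCCC[C@H]43)nc(N)c2cc1OC`: 1.38 nM
compound 2, `COc1cc2nc(N3CCN(C(=O)c4cccs4)[C@H]4CCCC[C@H]43)nc(N)c2cc1OC`: 0.24 nM

Compound 2 holds the lowest number of the two in this assay, and its nearest neighbour is compound 1, separated by a 5.8-fold lower number from compound 1 to compound 2 (0.76 log units; beyond the scatter). For the measured compounds named here, that single step, exchanging one five-membered heteroaryl on the carbonyl carbon for another, is the only measured change of this kind and was of modest size.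

Compound 3, `COc1cc2nc(N3CCN(C(=O)c4ccc[nH]4)[C@H]4CCCC[C@H]43)nc(N)c2cc1OC`, has not yet been measured. It differs from compound 2 by 1H-pyrrol-2-yl in place of thiophen-2-yl on a carbonyl carbon. Going by the values given here, the one measured step bears on it only loosely, since the ring swap there went in a different direction and involved a different ring. With a swap of comparable kind in hand, a step of modest size in either direction is possible; a small rise in the number seems the more likely outcome. Compound 3 is therefore expected to show a 2.5-fold higher number from compound 2 to compound 3 (0.40 log units; beyond the scatter), an estimate of 0.6 nM with a range from 0.15 nM to 2.5 nM.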

Compound 3, inhibition constant: 3.16 nM
Estimate against measurement, compound 3: 5.3-fold (0.72 log units) below; the measured number lies above the stated range.
By their numbers in this assay, from the lowest: compound 2; then compound 1; then compound 3.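

In this assay, the exchange on this carbonyl carbon gives a 13-fold higher number from compound 2 to compound 3 (1.12 log units; beyond the scatter), so two rings with the same count of heavy atoms, one five-membered aromatic ring with 1 hetero atom each, are far from interchangeable here. For the compounds shown here, this step exceeds a 5.8-fold lower number from compound 1 to compound 2 (0.76 log units; beyond the scatter), the only change at this place seen earlier. The unsubstituted 1H-pyrrol-2-yl also falls behind the substituted 5-acetylfuran-2-yl, with a 2.3-fold higher number from compound 1 to compound 3 (0.36 log units; beyond the scatter) as the step, which places the acetylated ring between the two unsubstituted rings in these three compounds.

No measurement available here explains why the sulfur-bearing ring and the nitrogen-bearing ring differ so much. Going by these compounds, it remains open whether 1-methyl-1H-pyrrol-2-yl, which lacks the ring hydrogen on nitrogen, or plain furan-2-yl would fall nearer compound 2 or compound 3.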